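The source may hold more compounds than are shown below. What is called first, only, known or untested is meant among the compounds shown, and "the series" means these compounds.

Of the compounds shown here, two carrying the same amide-linked core have been measured in a functional assay on MCF7 cells (Homo sapiens) for cytotoxicity, read by MTT assay, with a stated time of 24 h; on this read-out higher numbers stand for weaker inhibition and lower numbers for stronger inhibition. Compound 1 `Cc1ccc2oc(-c3ccc(NC(=O)CN4CCN(CCCN(C)C)CC4)cc3)nc2c1` gives 19100 nM. Compound 2 `CN(C)CCN1CCN(CC(=O)Nc2ccc(-c3nc4cc(Cl)ccc4o3)cc2)CC1` gives 7920 nM, the lower of the two numbers; compound 1 sits higher by a gap that lies beyond the usual scatter, so compound 2 is the stronger inhibitor of this pair.

Compound 3 `CN(C)CCCN1CCN(CC(=O)Nc2ccc(-c3nc4cc(Cl)ccc4o3)cc2)CC1` has not yet been measured. It differs from compound 2 in one place: (dimethylamino)methyl in place of dimethylamino on a saturated chain carbon, two bonds along the chain from an amine nitrogen in a ring. Compound 1 already carries the longer chain, but on a different core, so there is no measured pair that isolates this chain lengthening, and nothing shown tells its direction.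

The step from compound 2 to compound 3 is therefore expected to be small, in either direction, and not beyond the scatter. Compound 3 is expected to give 9000 nM, within a range from 4000 nM to 20000 nM. That estimate means a step of a 1.1-fold higher number from compound 2 to compound 3 (0.06 log units; within the scatter), expected to stay inside the usual scatter.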

Compound 3, half-maximal inhibitory concentration: 1650 nM
Beside the measured number, compound 3's estimate is 5.5-fold (0.74 log units) above it, and the stated range ends above it.
By their numbers in this assay, from the lowest: compound 3; then compound 2; then compound 1.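

Lengthening the chain by one carbon is not a neutral change at this position: in this assay it gives a 4.8-fold lower number from compound 2 to compound 3 (0.68 log units; beyond the scatter) on the chloro-bearing core. Within the data shown here, compound 3 also forms the first measured pair that isolates the aromatic substituent, since with the longer chain held constant, chloro in place of methyl on an aromatic carbon gives a 12-fold lower number from compound 1 to compound 3 (1.06 log units; beyond the scatter) and shows that this site matters as well. Nothing shown here explains either step.

Among these compounds, only two chain lengths have been compared on the chloro-bearing core, so it remains open whether a still longer chain, such as 4-(dimethylamino)butyl, would bring a further drop in the number or reverse it. From the compounds shown here alone, it is also open whether a bromo or a methoxy group on that aromatic carbon would match chloro, and whether a chain ending in a morpholine ring would hold the gain.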